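Furanyl ketone variant of the benzhydryl penam series

A few compounds are considered here, and "the series" means these few. Any claim that something is new, unique, unknown or untested is made for them only; others in the source may bear on it.

The series shares the core of compound 1 `CC1(C)S[C@@H]2/C(=C\C(=O)c3ccc(F)cc3)C(=O)N2[C@H]1C(=O)OC(c1ccccc1)c1ccccc1` with a benzhydryl ester and an exocyclic enone. In a functional assay on HT-1080 cells (Homo sapiens) for cytotoxicity, read by MTT assay, with a stated time of 48 h (on this read-out lower numbers stand for stronger inhibition and higher numbers for weaker inhibition), compound 1 gives 11200 nM. Compound 2 `CC1(C)S[C@@H]2/C(=C\C(=O)OC(c3ccccc3)c3ccccc3)C(=O)N2[C@H]1C(=O)OC(c1ccccc1)c1ccccc1`, carrying a benzhydryl ester in place of the aryl ketone, gives 15200 nM in this assay, and the two values sit within the scatter of each other. Compound 3 `CC(=O)/C=C1\C[C@H]2SC(C)(C)[C@H](C(=O)OC(c3ccccc3)c3ccccc3)N2C1=O`, in which the enone is shifted onto a methyl ketone, reaches only the assay limit of > 100000 nM in this assay, which is a limit and not a number. Beyond that, the limit of > 100000 nM in this assay, at which 1 of the 3 values shown sits, is the only evidence on what the read-out tolerates.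

Compound 4 `CC1(C)S[C@@H]2/C(=C\C(=O)c3ccco3)C(=O)N2[C@H]1C(=O)OC(c1ccccc1)c1ccccc1` is the next member. It differs from compound 1 in one place: furan-2-yl in place of 4-fluorophenyl on a carbonyl carbon. Going by the values given here, no measured pair carries that change, so any expectation rests on compound 1 alone. The step from compound 1 to compound 4 is expected to be small, a 1.3-fold higher number from compound 1 to compound 4 (0.13 log units; within the scatter), with no clear direction beyond the scatter. For compound 4 in this assay a value of 15000 nM is estimated, within the range 5000 nM to 45000 nM.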

Compound 4, half-maximal inhibitory concentration: 45500 nM
Beside the measured number, compound 4's estimate is 3.0-fold (0.48 log units) below it; measured number above the stated range.
By their numbers in this assay, from the lowest: compounds 1 and 2 (each within the scatter of the next); then compound 4. At a limit, above all of these: compound 3.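

In this assay, going by these compounds alone, this is the first step between compounds differing in one place, and it shows that the group on a carbonyl carbon can shift the read-out: a 4.1-fold higher number from compound 1 to compound 4 (0.61 log units; beyond the scatter). The change swaps a six-membered aromatic ring of carbon only for a five-membered aromatic ring with 1 hetero atom, and it also removes the fluorine, so this single step cannot separate ring size, hetero atom and fluorine from one another. Nothing measured here gives a reason for the step.

Still open, going by these compounds, is whether plain phenyl or thiophen-2-yl on the same carbonyl carbon would follow compound 1 or compound 4. Also open, on these data alone, is how a ring carrying an amine or a carboxylic acid would read at this place.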